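This account rests on a few compounds, and the source may have more. Where it says the series, first, only, none or still open, it means among the compounds named here.

Compound 1 `CCCCOc1ccc(C(CC)NC(=O)Oc2cccc(C(F)(F)F)c2)cc1` gives 51 nM in an assay on H4 cells for inhibition of Fatty-acid amide hydrolase 1 (Homo sapiens); a lower number here means a stronger inhibitor, a higher number a weaker inhibitor. Among the three measured compounds it stands second highest: compound 2 `CCCCOc1ccc(C(CC)NC(=O)Oc2cccc(N(C)C)c2)cc1` gives 54 nM, and the step of a 1.1-fold higher number from compound 1 to compound 2 (0.02 log units; within the scatter) lies within the scatter, whereas compound 3 `CCCCOc1ccc(C(CC)NC(=O)Oc2ccccc2)cc1` gives 12 nM, reached by a 4.3-fold lower number from compound 1 to compound 3 (0.63 log units; beyond the scatter). The step of a 4.5-fold lower number from compound 2 to compound 3 (0.65 log units; beyond the scatter) is of the same modest size.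

Compound 4 `CCCCOc1ccc(CNC(=O)Oc2cccc(C(F)(F)F)c2)cc1` differs from compound 1 by hydrogen in place of ethyl on a saturated chain carbon bound to an amide-type nitrogen and an aromatic carbon. Among the compounds with values here, none of the measured steps bears on this place: each of them exchanges a group on an aromatic carbon, and the saturated chain carbon carrying the ethyl is the same in compounds 1, 2 and 3. Within the data shown here, the measured steps therefore offer no direct precedent, and the shared core, which has not been varied at this carbon, gives no further hint. In the absence of a matching step, the author expects a modest move toward a higher number in this assay, a 2.4-fold higher number from compound 1 to compound 4 (0.37 log units; beyond the scatter). The estimate for compound 4 in this assay is 120 nM, with a range from 35 nM to 400 nM.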

Compound 4, half-maximal inhibitory concentration: 40 nM
Estimate against measurement, compound 4: 3.0-fold (0.48 log units) above; measured number inside the range.
By their numbers in this assay, from the lowest: compound 3; then compounds 4, 1 and 2 (each within the scatter of the next).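

Within the data shown here, this is the first look at the saturated chain carbon bound to an amide-type nitrogen and an aromatic carbon, since every earlier step exchanged a group on an aromatic carbon. In this assay, hydrogen in place of ethyl at this carbon gives no change beyond the scatter (a 1.3-fold lower number from compound 1 to compound 4 (0.11 log units; within the scatter)). With trifluoromethyl on the aromatic ring, the ethyl is therefore not needed to keep the number at this level, although nothing shown here explains why this exchange is tolerated.

From the compounds shown here alone, it remains open whether a longer chain, such as propyl or butyl, or a hydroxymethyl group or a phenyl ring at this carbon would give the same reading. Also open, going by these compounds, is whether hydrogen in place of ethyl would be tolerated equally in compound 3 or in compound 2, which carry hydrogen and dimethylamino in place of the trifluoromethyl.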